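A few compounds are considered here, and "the series" means these few. Any claim that something is new, unique, unknown or untested is made for them only; others in the source may bear on it.

Compound 1 `O=C([C@@H]1CCCN(S(=O)(=O)c2ccc(S(=O)(=O)C3COC3)cc2)C1)N1CCC(F)(F)CC1` gives 110 nM in a functional assay on MIA PaCa-2 cells (Homo sapiens) for inhibition, read by MTT assay, with a stated time of 7 days; on this read-out higher numbers stand for weaker inhibition and lower numbers for stronger inhibition. Compound 2 `CN(C)S(=O)(=O)c1ccc(S(=O)(=O)N2CCC[C@@H](C(=O)N3CCC(F)(F)CC3)C2)cc1` gives 118 nM in this assay, and the step of a 1.1-fold higher number from compound 1 to compound 2 (0.03 log units; within the scatter) shows that the two numbers sit within the scatter of each other, so on the numbers shown compound 2 stands level with compound 1 and apart from nothing. Compound 3 `O=C([C@@H]1CCCN(S(=O)(=O)c2ccc(S(=O)(=O)N3CC[C@H](O)C3)cc2)C1)N1CCC(F)(F)CC1` differs from compound 2 by 3-hydroxypyrrolidin-1-yl in place of dimethylamino on a sulfonyl sulfur, on a sulfonyl sulfur whose other neighbours are aromatic carbon. Going by the values given here, the only measured step at this position, a 1.1-fold higher number from compound 1 to compound 2 (0.03 log units; within the scatter), exchanged oxetan-3-yl for dimethylamino and stayed within the scatter. Exchanging dimethylamino for 3-hydroxypyrrolidin-1-yl at the same sulfonyl sulfur is therefore expected to give a step of about a 1.0-fold higher number from compound 2 to compound 3 (0.01 log units; within the scatter) in this assay, that is no step beyond the scatter. Compound 3 is accordingly estimated at 120 nM, with a range of 50 nM to 300 nM.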

Compound 3, half-maximal inhibitory concentration: 590 nM
Estimate against measurement, compound 3: 4.9-fold (0.69 log units) below; measured number above the stated range.
By their numbers in this assay, from the lowest: compounds 1 and 2 (each within the scatter of the next); then compound 3.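

At the sulfonyl sulfur whose other neighbours are aromatic carbon, the group is no longer interchangeable in this assay: 3-hydroxypyrrolidin-1-yl in place of dimethylamino gives a 5.0-fold higher number from compound 2 to compound 3 (0.70 log units; beyond the scatter), and in place of oxetan-3-yl it gives a 5.4-fold higher number from compound 1 to compound 3 (0.73 log units; beyond the scatter). The position therefore responds to at least this exchange, which the earlier step within the scatter did not show. Nothing available bears on the reason for this rise.

The ring, the hydrogen-bond donor and the defined stereocentre enter together, so the compounds shown do not separate their contributions. Unsubstituted pyrrolidin-1-yl would separate the ring from the hydroxyl, and the opposite enantiomer of 3-hydroxypyrrolidin-1-yl would test the stereocentre.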